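The source may report more compounds than this note shows. Statements on the series, on what has been measured and on what is new or still open speak of the compounds shown alone.

Of the compounds shown here, three that share one core have been tested in a functional assay for inhibition, with Homo sapiens as the target; on this read-out lower numbers stand for an effect already at smaller amounts and higher numbers for an effect only at larger amounts of compound. Compound 1 `CCC(=O)Nc1ccc(C2=NNC(=O)CC2)cc1` gives 0.64 ug/mL, the lowest of the two numbers obtained. Compound 2 `CC(=O)Nc1ccc(C2=NNC(=O)C(C)C2)cc1` gives 46.4 ug/mL, a far higher number, well beyond the scatter of repeated runs. Compound 3 `CC(=O)Nc1cccc(C2=NNC(=O)CC2)c1` yields only > 46.4 ug/mL, which is a limit of the assay rather than a number; this is the limit of > 46.4 ug/mL in this assay, at which 1 of the 3 values shown sits.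

Compound 4 `CC(C)NCC(=O)Nc1ccc(C2=NNC(=O)CC2)cc1` has not yet been measured. It differs from compound 1 in one place: isopropylamino in place of methyl on a saturated chain carbon bound to a carbonyl carbon. Within the data shown here, no pair of measured compounds differs in exactly this way, so there is no measured step to lean on; the core and the amide stay as they are in compound 1, and only the chain attached to the carbonyl changes. In this assay compound 4 is expected to give about 1.5 ug/mL, with a likely range from 0.4 ug/mL to 8 ug/mL. The step of a 2.3-fold higher number from compound 1 to compound 4 (0.37 log units; beyond the scatter) is expected to be modest, towards a somewhat higher number, close to the edge of the scatter.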

Compound 4, half-maximal effective concentration: about 46.4 ug/mL
Compound 4: middle estimate off by 31-fold (1.49 log units), on the low side; measured number above the stated range.
By their numbers in this assay, from the lowest: compound 1; then compounds 2 and 4 (each within the scatter of the next).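

In this assay, this place on the chain proves far from free to change: a 73-fold higher number from compound 1 to compound 4 (1.86 log units; beyond the scatter), a large step, with isopropylamino in place of methyl on a saturated chain carbon bound to a carbonyl carbon. Among these compounds, no earlier pair showed what a change here does, and this one shows that the shared core and the amide alone do not preserve the low number of compound 1. Compound 4 also stands near the top of what this assay can read: the limit of > 46.4 ug/mL in this assay, at which 1 of the 4 values shown sits.

A single pair cannot tell whether the amine nitrogen or the larger isopropylamino group as a whole accounts for the step. Also open, on these data alone, is whether a smaller amine such as methylamino, or a plain longer carbon chain such as butyl, would keep the low number of compound 1.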